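The compounds below may be only part of what the source reports. "The series", "measured", "known", "first", "only" and "open" are said of these compounds alone.

Three compounds have so far been measured in a functional assay on DU-145 cells (Homo sapiens) for inhibition, read by trypan blue exclusion, with a stated time of 96 h; on this read-out lower numbers stand for stronger inhibition of growth and higher numbers for weaker inhibition of growth:

compound 1 `COc1ccccc1/C=C(/SCc1ccc(Cl)c(Cl)c1)C(=O)c1ccc(Cl)cc1`: 10000 nM
compound 2 `COc1ccccc1/C=C(\C(=O)c1ccc(Br)cc1)S(=O)(=O)c1ccc(C)cc1`: 1000 nM
compound 3 `Cc1ccsc1/C=C(/SCc1ccc(Cl)c(Cl)c1)C(=O)c1ccc(Cl)cc1`: 50000 nM

Compound 2 gives the lowest number of the three, and its steps to compound 1 and to compound 3 both lie beyond the scatter. The difference between the core of compound 2 and the core of compound 1 is not broken down here. Compound 1 and compound 3, by contrast, differ in one place only: 3-methylthiophen-2-yl in place of 2-methoxyphenyl on a double-bonded chain carbon bound to a double-bonded chain carbon. That change brought a 5.0-fold higher number from compound 1 to compound 3 (0.70 log units; beyond the scatter).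

Compound 4 `Cc1ccc(S(=O)(=O)/C(=C/c2sccc2C)C(=O)c2ccc(Br)cc2)cc1` has not yet been measured. It stands to compound 2 as compound 3 stands to compound 1: 3-methylthiophen-2-yl in place of 2-methoxyphenyl on a double-bonded chain carbon bound to a double-bonded chain carbon. The place is the same in both pairs, so this is the same change carried out on a different core. Among the measured compounds shown here, only one measured instance of the change exists, and because a 5.0-fold higher number from compound 1 to compound 3 (0.70 log units; beyond the scatter) is that instance, compound 4 is expected to show a 5.0-fold higher number from compound 2 to compound 4 (0.70 log units; beyond the scatter). In this assay compound 4 is therefore estimated at 5000 nM, with a likely range from 1500 nM to 20000 nM.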

Compound 4, concentration for 50% growth inhibition: 25000 nM
Estimate against measurement, compound 4: 5.0-fold (0.70 log units) below, outside the stated range (above it).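

In this assay, replacing 2-methoxyphenyl with 3-methylthiophen-2-yl raised the number on both cores, and on the core of compound 2 the change brought a 25-fold higher number from compound 2 to compound 4 (1.40 log units; beyond the scatter). The direction of the change therefore carried over from one core to the other, but its size did not: the same change on two cores in this assay, a 5.0-fold higher number (0.70 log units; beyond the scatter) from compound 1 to compound 3 and a 25-fold higher number (1.40 log units; beyond the scatter) from compound 2 to compound 4, 5.0-fold (0.70 log units) apart, beyond the scatter of two such steps These two pairs show that the size of this step cannot simply be transferred between these cores, but they do not show which part of the core matters, as the core of compound 1 and the core of compound 2 differ in more than one place.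

The compounds shown leave open how much of the gap between the two steps would remain on a core that differs from the core of compound 1 in one place only. They also leave open how the step would run with a pyridin-2-yl ring or a phenyl ring bearing a carboxylic acid in the same place.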